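The source may hold more compounds than are shown below. What is called first, only, known or untested is meant among the compounds shown, and "the series" means these compounds.

Measured so far:
- compound 1, `C[C@@H](C(=O)O)c1nn(Cc2cn3cc(OCC4CC4)c(Cl)cc3n2)c2ccccc2c1=O`: 182 nM
- compound 2, `C[C@H](C(=O)O)n1nc(Cn2cc3cc(OCC4CC4)c(Cl)cc3n2)c2ccccc2c1=O`: 3.5 nM

Going by the values given here, compound 1 gives the highest of the two numbers in a functional assay on HFL1 cells for antagonist activity at sphingosine 1-phosphate receptor 2 (Homo sapiens), read by ELISA, with a stated time of 24 h; on this read-out higher numbers stand for weaker inhibition and lower numbers for stronger inhibition; the only neighbour, compound 2, sits well below it, and that gap lies beyond the usual scatter. Among the compounds with values here, no step between these two is counted here, so only the two values themselves can be compared.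

Compound 3, `C[C@H](C(=O)O)c1nn(Cc2cn3cc(OCC4CC4)c(Cl)cc3n2)c2ccccc2c1=O`, has not yet been measured. It differs from compound 1 in a single way: the two compounds have the same atoms and bonds and differ only in configuration as drawn: 1 of 1 stereo elements differ; a stereocentre at a saturated chain carbon is drawn R in compound 1 and S in compound 3. Nothing leaves and nothing enters.

Within the data shown here, with no measured step of this kind, the size of the step is open. Since a change of configuration at a single centre can shift a result a great deal or not at all, and compound 1 holds the weaker end of the two values, the step from compound 1 to compound 3 is expected to move toward a lower number, a 4.6-fold lower number from compound 1 to compound 3 (0.66 log units; beyond the scatter). Compound 3 is therefore estimated at 40 nM, in a range from 5 nM to 400 nM.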

Compound 3, half-maximal inhibitory concentration: 2.1 nM
The estimate for compound 3 lay 19-fold (1.28 log units) above the measured number; measured number below the stated range.
By their numbers in this assay, from the lowest: compounds 3 and 2 (each within the scatter of the next); then compound 1.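

On this assay, the stereocentre at the saturated chain carbon proves decisive, and redrawing it from R to S gives an 87-fold lower number from compound 1 to compound 3 (1.94 log units; beyond the scatter). Before this, no two measured compounds differed in one place only, so the effect of this position could not be read on its own. The size of the step can now be put down to this one carbon alone, because nothing else separates the pair: the fact that compounds 1 and 3 differ only in the configuration as drawn

The compounds shown do not reveal whether the preference for S holds when the carboxylic acid on this chain is replaced by a primary amide, or when the methyl group on the stereocentre gives way to an ethyl group. They also leave open how the change acts at the receptor, since the numbers show its size but not its mechanism.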